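Swapping a Propyl Chain for a Fluorophenyl Ring

The source may hold more compounds than are shown below. What is called first, only, known or untested is meant among the compounds shown, and "the series" means these compounds.

Of the compounds shown here, three sharing one core have been tested in an ADME assay on HeLa cells (Homo sapiens) for cytotoxicity, read by sulforhodamine B assay, with a stated time of 48 h, tested at 10 uM; on this read-out higher numbers stand for more inhibition at the one concentration tested (going by the name of the read-out) and lower numbers for less inhibition. Compound 1, `COc1nc2ccc(Br)cc2cc1C(c1ccccc1)n1cc(-c2ccc(Br)cc2)nn1`, gives 6.92%. Compound 2, `COc1nc2ccc(Br)cc2cc1C(c1ccccc1)n1cc(CCCO)nn1`, gives 11.3%. Compound 3, `CCCc1cn(C(c2ccccc2)c2cc3cc(Br)ccc3nc2OC)nn1`, gives -2.25%. On these three numbers compound 3 stands lowest, but the gaps are uneven: the step of a number 9.2 percentage points lower from compound 1 to compound 3 (within the scatter) is small, whereas the step of a number 13.6 percentage points lower from compound 2 to compound 3 (beyond the scatter) is larger.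

Compound 4, `COc1nc2ccc(Br)cc2cc1C(c1ccccc1)n1cc(-c2cccc(F)c2)nn1`, has not yet been measured. It differs from compound 3 in one place: 3-fluorophenyl in place of propyl on an aromatic carbon. The closest guide is the reverse of the measured step in which a propyl chain replaced a 4-bromophenyl ring on an aromatic carbon, a number 9.2 percentage points lower from compound 1 to compound 3 (within the scatter), a change within the scatter. Putting an aromatic ring back on that aromatic carbon is therefore expected to move the number only slightly upward, if at all, and not beyond the scatter. The other steps, a number 4.4 percentage points higher from compound 1 to compound 2 (within the scatter) and a number 13.6 percentage points lower from compound 2 to compound 3 (beyond the scatter), concern the hydroxy group and do not bear directly on this change.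

Compound 4 is estimated at 5%, with a range from -8% to 18%. This estimate means a step of a number 7.3 percentage points higher from compound 3 to compound 4 (within the scatter), expected to stay within the usual scatter.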

Compound 4, a percentage reported as inhibition, at one concentration (the size of the read-out at that concentration, not a potency): 9.04%
Compound 4: middle estimate off by 4 percentage points, on the low side; low and high end bracket the measured number.
By their numbers in this assay, from the lowest: compounds 3, 1, 4 and 2 (each within the scatter of the next, the first and the last beyond it).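

In this assay the swap of propyl for 3-fluorophenyl gives a number 11.3 percentage points higher from compound 3 to compound 4 (beyond the scatter) and so shows that this aromatic carbon can register a change of group, which the earlier step between propyl and 4-bromophenyl did not. For the compounds shown here, the other two comparisons stay close: 4-bromophenyl against 3-fluorophenyl gives a number 2.1 percentage points higher from compound 1 to compound 4 (within the scatter) and 3-hydroxypropyl against 3-fluorophenyl gives a number 2.3 percentage points lower from compound 2 to compound 4 (within the scatter) and neither group can be ranked against 3-fluorophenyl, so among the changes to compound 4 only the one from propyl stands out, even though compound 1 stays within the scatter of compound 3. Nothing measured here accounts for that single larger step.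

Going by these compounds, it remains open whether a group of another kind on this carbon, such as an amine, a carboxylic acid or a longer chain ending in a hydroxy group, would move the number well clear of these four compounds. On these data alone, it is also open how a plain phenyl ring would compare with 3-fluorophenyl, so the part played by the fluorine itself cannot be judged from these compounds.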